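Chloro for fluoro on the phenyl ring of compound 2

This account rests on a few compounds, and the source may have more. Where it says the series, first, only, none or still open, it means among the compounds named here.

Of the compounds shown here, two sharing one core have been measured so far. In a functional assay on SW-620 cells (Homo sapiens) for inhibition, read by MTT assay, with a stated time of 72 h (on this read-out lower numbers stand for stronger inhibition and higher numbers for weaker inhibition), compound 1 `COc1cc(NC(C)CCCNC(=O)NNC(=O)Nc2ccc(Cl)cc2)c2ncccc2c1` gives 48000 nM while compound 2 `COc1cc(NC(C)CCCNC(=O)NNC(=O)Nc2cccc(F)c2)c2ncccc2c1` gives 9500 nM and so holds the lower of just two numbers. The next compound is compound 3 `COc1cc(NC(C)CCCNC(=O)NNC(=O)Nc2cccc(Cl)c2)c2ncccc2c1` and it differs from compound 2 by a single exchange: chloro in place of fluoro on an aromatic carbon. So the halogen changes while its place, meta to a large group, stays the same.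

Going by the values given here, only one measured step bears on this change. It is a 5.1-fold lower number from compound 1 to compound 2 (0.70 log units; beyond the scatter) and it alters the halogen and its place on the ring together, so it does not show what the halogen alone contributes. Compound 3 carries chloro as compound 1 does, but in the place that compound 2 has fluoro. No step beyond the usual scatter is therefore expected in this assay, with at most a slight drift towards a higher number. The expected step is a 1.2-fold higher number from compound 2 to compound 3 (0.06 log units; within the scatter) and this remains only an estimate. For compound 3 the estimated value is 11000 nM (expected range 4500 nM to 28000 nM).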

Compound 3, half-maximal inhibitory concentration: 25000 nM
Compound 3: the middle estimate sits 2.3-fold (0.36 log units) below what was measured; low and high end bracket the measured number.
By their numbers in this assay, from the lowest: compound 2; then compounds 3 and 1 (each within the scatter of the next).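

With the place on the ring held fixed, the halogen can now be read alone: in this assay the exchange of fluoro for chloro gives a 2.6-fold higher number from compound 2 to compound 3 (0.42 log units; beyond the scatter), so the two halogens are not interchangeable here. The other half of the earlier combined change can also be read alone, since moving chloro from the 4-chlorophenyl to the 3-chlorophenyl arrangement gives a 1.9-fold lower number from compound 1 to compound 3 (0.28 log units; within the scatter), which does not show that the place of chloro matters on its own, and this suggests that the halogen exchange contributes at least as clearly as the change of place to a 5.1-fold lower number from compound 1 to compound 2 (0.70 log units; beyond the scatter). Nothing in the data accounts for why fluoro and chloro differ at this position.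

The compounds shown cover only two halogens in this place, so it remains open whether a bromo or a methoxy group would follow chloro or fluoro there, and what a plain phenyl would give as a reference. On these data alone, it is also open whether the gap between fluoro and chloro holds on other cell lines or with a change in the chain of the shared core.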